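A few compounds are considered here, and "the series" means these few. Any claim that something is new, unique, unknown or untested is made for them only; others in the source may bear on it.

Compound 1 `C=C1C(=O)[C@]23C[C@@]1(O)CC[C@H]2c1ccc(OS(=O)(=O)c2ccc(C)cc2)c(C)c1[C@@H]3Cn1cc(-c2ccccn2)nn1` — 1970 nM
Compound 2 `C=C1C(=O)[C@]23C[C@@]1(O)CC[C@H]2c1ccc(O)c(C)c1[C@@H]3Cn1cc(-c2ccccn2)nn1` — 410 nM
Compound 3 `C=C1C[C@]23C[C@@]1(O)CC[C@@H]2c1cccc(C)c1[C@@H]3Cn1cc(-c2ccc(Br)cc2)nn1` — > 20000 nM

In a functional assay on SW480 cells (Homo sapiens) for cytotoxicity, read by MTT assay, with a stated time of 4 days (a higher number here means a weaker inhibitor, a lower number a stronger inhibitor), compound 2 gives 410 nM, the lowest of the two numbers measured. Among the measured compounds shown here, its nearest neighbour is compound 1, and the one measured step, a 4.8-fold lower number from compound 1 to compound 2 (0.68 log units; beyond the scatter), concerns only the oxygen on the aromatic ring. The value of compound 3 is a limit of the assay, (the limit of > 20000 nM in this assay, at which 1 of the 3 values shown sits), not a number. Compound 3 also differs from compound 2 in more than one place, so it cannot be read as a single step.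

Compound 4 `C=C1C(=O)[C@]23C[C@@]1(O)CC[C@H]2c1ccc(O)c(C)c1[C@@H]3Cn1cc(-c2ccc(Cl)cc2)nn1` is not yet measured. It differs from compound 2 by 4-chlorophenyl in place of pyridin-2-yl on an aromatic carbon. For the measured compounds named here, no measured step touches this arm of the molecule, so the change from compound 1 to compound 2 says nothing directly about it. The expectation for compound 4 therefore rests on little, and a step of about a 2.0-fold higher number from compound 2 to compound 4 (0.29 log units; within the scatter) in this assay is estimated, leaning towards a somewhat higher number. Compound 4 is expected to give about 800 nM, within a range from 250 nM to 3000 nM.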

Compound 4, half-maximal inhibitory concentration: 280 nM
Compound 4: middle estimate off by 2.9-fold (0.46 log units), on the high side; low and high end bracket the measured number.
By their numbers in this assay, from the lowest: compounds 4 and 2 (each within the scatter of the next); then compound 1. At a limit, above all of these: compound 3.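

On the aromatic carbon of the five-membered aromatic ring with 3 nitrogen, placing 4-chlorophenyl where pyridin-2-yl stood gives a 1.5-fold lower number from compound 2 to compound 4 (0.17 log units; within the scatter) in this assay. Among the compounds shown here, this is the first measured step on this arm of the molecule, and it shows that the two compounds cannot be told apart in this assay, so the ring nitrogen of pyridin-2-yl is not required for a value in this range on this core. The compounds shown offer no measured reason for this result.

From the compounds shown here alone, whether an amine or a carboxylic acid on the phenyl ring, in place of the chlorine, would also stay in this range remains open. Also open, going by these compounds, is whether the same exchange would read alike with the (4-methylphenyl)sulfonyl group of compound 1 on the oxygen.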